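Methoxy to chloro on the aryl ring, two backbones

The source may report more compounds than this note shows. Statements on the series, on what has been measured and on what is new or still open speak of the compounds shown alone.

Compound 1 `COc1cccc(/C=C/C(=O)Nc2nc3ccccc3c(=O)s2)c1` and compound 2 `COc1cccc(/C=C/CC(=O)Nc2nc3ccccc3c(=O)s2)c1` share most of their structure; the difference between the two cores is not broken down here. In an assay on membranes from brain for displacement of a labelled ligand from adenosine receptor A1 (Rattus norvegicus), read by scintillation counting, with a stated time of 90 min (on this read-out lower numbers stand for stronger inhibition and higher numbers for weaker inhibition), compound 1 gives 205 nM, while compound 2 gives 11.2 nM. Compound 3 `O=C(C/C=C/c1cccc(Cl)c1)Nc1nc2ccccc2c(=O)s1` carries one change relative to compound 2, (chloro in place of methoxy on an aromatic carbon). In this assay compound 3 gives 11.4 nM, so the step of a 1.0-fold higher number from compound 2 to compound 3 (0.01 log units; within the scatter) lies within the scatter. Compound 4 `O=C(/C=C/c1cccc(Cl)c1)Nc1nc2ccccc2c(=O)s1` carries the same change relative to compound 1, (chloro in place of methoxy on an aromatic carbon), at a place described in the same words. Because the step of a 1.0-fold higher number from compound 2 to compound 3 (0.01 log units; within the scatter) left the number essentially unchanged, the expected step of no change at the digits printed from compound 1 to compound 4 (within the scatter) is small. Compound 4 is therefore estimated at 205 nM, with a likely range from 80 nM to 520 nM.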

Compound 4, inhibition constant: >= 10000 nM
Compound 4: only a limit was reported; the forecaster's own chance of this, stated with the estimate: 3%; middle value at least 48-fold (1.68 log units) from the limit.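

On the core of compound 1, chloro in place of methoxy gives an at least 48-fold higher number from compound 1 to compound 4 (1.68 log units; beyond the scatter) in this assay, so the flat result on the core of compound 2 does not carry over: the same change on two cores in this assay, a 1.0-fold higher number (0.01 log units; within the scatter) from compound 2 to compound 3 and an at least 48-fold higher number (1.68 log units; beyond the scatter) from compound 1 to compound 4, at least 47-fold (1.68 log units) apart, beyond the scatter of two such steps

Compound 4 sits at a limit of the assay, >= 10000 nM, not at a number, so the full size of its step stays unread: the limit of >= 10000 nM in this assay, at which 1 of the 4 values shown sits.

One pair on each core shows that the result of this change depends on the core in this series, but it gives no reason for that and no rule for other cores.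

Open, on these data alone, is whether a fluoro, methyl or hydroxy group in place of the methoxy on the core of compound 1 behaves like chloro. Also open, as far as these compounds go, is how those groups compare on the core of compound 2.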